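Two Sulfonamides at the Limit, One Aryl Swap Ahead

The source may report more compounds than this note shows. Statements on the series, on what has been measured and on what is new or still open speak of the compounds shown alone.

Compound 1 `O=S(=O)(Nc1ccc(-c2nc3ccccc3o2)cc1)c1ccccc1O` and compound 2 `O=S(=O)(Nc1ccc2oc(-c3ccccc3)nc2c1)c1cccs1` carry a sulfonamide on related aromatic cores. In an assay on isolated protein for inhibition of malate dehydrogenase, mitochondrial (Sus scrofa), with stated times of 45 min and 30 min (on this read-out lower numbers stand for stronger inhibition and higher numbers for weaker inhibition), compound 1 gives only a limit, > 63000 nM, not a measured number. In this assay compound 2 likewise gives only a limit, > 63000 nM. Compound 2 therefore stands at the limit of > 63000 nM in this assay, at which 2 of the 2 values shown sit. Compound 3 `COc1ccc(Cl)cc1S(=O)(=O)Nc1ccc2oc(-c3ccccc3)nc2c1` differs from compound 2 in one place: 5-chloro-2-methoxyphenyl in place of thiophen-2-yl on a sulfonyl sulfur. Going by the values given here, no step between measured compounds exists here, so the expected step that the limit leaves unreadable from compound 2 to compound 3 is none beyond the usual scatter. Compound 3 is estimated at 80000 nM, within 30000 nM to 250000 nM.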

Compound 3, half-maximal inhibitory concentration: > 63000 nM
Compound 3 gave a limit, no number; the forecaster's own chance of this, stated with the estimate: 70%; the middle value does not contradict the limit.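

Going by these compounds alone, compound 2 and compound 3 both give only limits, and no step between them can be read. The compounds shown leave open which group on the sulfonyl sulfur, if any, would give a measured number in this assay.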